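From 2,5-dimethoxyphenyl to 2,4-dimethoxyphenyl: an estimate for compound 3

This account rests on a few compounds, and the source may have more. Where it says the series, first, only, none or still open, it means among the compounds named here.

Measured in a functional assay on A549 cells (Homo sapiens) for inhibition, read by sulforhodamine B assay, with a stated time of 48 h; on this read-out lower numbers stand for stronger inhibition of growth and higher numbers for weaker inhibition of growth:
Compound 1 `COc1cc(C=C(C(=O)/C=C/c2ccc(OC)c(OC)c2)C(=O)/C=C/c2ccc(OC)c(OC)c2)ccc1O`: 530 nM
Compound 2 `COc1ccc(OC)c(C=C(C(=O)/C=C/c2ccc(OC)c(OC)c2)C(=O)/C=C/c2ccc(OC)c(OC)c2)c1`: 530 nM

Going by the values given here, compound 2 stands at 530 nM, level with compound 1, the only other compound with a measured value. Compound 3 `COc1ccc(C=C(C(=O)/C=C/c2ccc(OC)c(OC)c2)C(=O)/C=C/c2ccc(OC)c(OC)c2)c(OC)c1` keeps the shared core of compound 2 and differs in one group: 2,4-dimethoxyphenyl in place of 2,5-dimethoxyphenyl on a double-bonded chain carbon bound to a double-bonded chain carbon. The two compounds therefore have the same atoms, joined differently.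

Among the compounds with values here, one measured step bears on this change. It is no change at the digits printed from compound 1 to compound 2 (within the scatter), and it concerns the same place on the chain, where 2,5-dimethoxyphenyl took the place of 4-hydroxy-3-methoxyphenyl. Within the data shown here, that single step is thin evidence, and no compound carrying 2,4-dimethoxyphenyl has a measured value yet. Even so, the only exchange seen at this place left this assay without a change beyond the scatter, so no step beyond the scatter is expected here, in either direction. The expected step is no change at the digits printed from compound 2 to compound 3 (within the scatter). For compound 3 the estimated value is 530 nM, with an expected range from 230 nM to 1200 nM.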

Compound 3, concentration for 50% growth inhibition: 650 nM
Estimate against measurement, compound 3: 1.2-fold (0.09 log units) below; the range from low to high includes it.
By their numbers in this assay, from the lowest: compounds 1, 2 and 3 (each within the scatter of the next).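

In this assay the exchange of 2,5-dimethoxyphenyl for 2,4-dimethoxyphenyl on a double-bonded chain carbon bound to a double-bonded chain carbon gives a 1.2-fold higher number from compound 2 to compound 3 (0.09 log units; within the scatter) and so stays within the scatter, which shows that rearranging the same atoms within this group leaves the read-out unmoved, something the earlier pair could not show. Set against the group of compound 1, 2,4-dimethoxyphenyl in place of 4-hydroxy-3-methoxyphenyl gives a 1.2-fold higher number from compound 1 to compound 3 (0.09 log units; within the scatter) and so also stays within the scatter, which means that all three groups seen at this place now lie within the scatter of one another and that a second, independent exchange agrees with the first. Nothing measured here offers an explanation for this agreement.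

The three compounds all carry an oxygen-substituted phenyl at this place, so they leave open whether the same flat picture would hold for a ring bearing an amine or a carboxylic acid, or for an unsubstituted phenyl. They also say nothing about changes elsewhere on the shared core, since every other part of it stays the same across compounds 1, 2 and 3.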